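Replacing the phenylethenyl of compound 2 with a benzyl

The compounds below may be only part of what the source reports. "The series", "measured", "known", "first", "only" and "open" are said of these compounds alone.

The shared core of this small set is an ethanesulfonamide whose nitrogen carries a pyridinylmethyl group and a phenyl ring, and the three measured compounds differ in what hangs from that phenyl ring. Compound 1 `CCS(=O)(=O)N(Cc1cccnc1)c1cccc(C(=O)c2ccccc2)c1` carries a benzoyl group and in an assay on isolated protein with metabotropic glutamate receptor 2 (Homo sapiens) as the target (on this read-out lower numbers stand for an effect already at smaller amounts and higher numbers for an effect only at larger amounts of compound), compound 1 gives 1100 nM. Compound 2 `C=C(c1ccccc1)c1cccc(N(Cc2cccnc2)S(=O)(=O)CC)c1` carries a 1-phenylethenyl group instead, and in this assay compound 2 gives 200 nM, the lowest number among the three. Compound 3 `CCS(=O)(=O)N(Cc1cccnc1)c1ccc(C(C)c2ccccc2)cc1` places a 1-phenylethyl group at a different position of the ring; in this assay compound 3 gives 1400 nM.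

Going by the values given here, the one single-point step that is known, a 5.5-fold lower number from compound 1 to compound 2 (0.74 log units; beyond the scatter), shows that swapping the carbonyl-linked benzoyl for the 1-phenylethenyl group improves the number substantially. Compound 4 `CCS(=O)(=O)N(Cc1cccnc1)c1cccc(Cc2ccccc2)c1` is the next variation: benzyl in place of 1-phenylethenyl on an aromatic carbon. Among the compounds with values here, no measured pair isolates exactly this change, so its effect has to be guessed from the fact that compound 2 is the best of the set and that the remaining, less active analogues do not carry the 1-phenylethenyl group. The expectation is a modest worsening, a 2.5-fold higher number from compound 2 to compound 4 (0.40 log units; beyond the scatter), in this assay. Compound 4 is therefore estimated at 500 nM, with a plausible range from 150 nM to 1700 nM.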

Compound 4, half-maximal effective concentration: 310 nM
Compound 4: the middle estimate sits 1.6-fold (0.21 log units) above what was measured, and the stated range covers the measured number.
By their numbers in this assay, from the lowest: compounds 2 and 4 (each within the scatter of the next); then compounds 1 and 3 (each within the scatter of the next).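

In this assay, a 1.6-fold higher number from compound 2 to compound 4 (0.19 log units; within the scatter), so at this place on the ring, meta to a large group, 1-phenylethenyl and benzyl cannot be told apart, even though the double bond outside the aromatic ring is gone in the benzyl group. Going by these compounds alone, this shows that the double bond is not required for a number in this range, something the earlier compounds could not reveal because none of them carried a plain benzyl group. The benzoyl comparison now has a second reference point: a 3.5-fold lower number from compound 1 to compound 4 (0.55 log units; beyond the scatter), so among the three compounds substituted at this place, the benzoyl of compound 1 stands apart from both groups that lack its carbonyl. No measurement here explains why the carbonyl compound gives the higher number.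

Going by these compounds, it remains open whether other links between the two aromatic rings, such as an ether oxygen, an amine or a longer two-carbon chain, would stay with benzyl or move towards benzoyl. Compound 3 differs from these compounds in more than one place, so it cannot show how a 1-phenylethyl group would behave at this same place.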